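The source may report more compounds than this note shows. Statements on the series, on what has been measured and on what is new or still open speak of the compounds shown alone.

Compound 1 `NC1=NC2(CCOCC2)N(OCCCOc2ccc(F)cc2)C(N)=N1` gives 2380 nM in a functional assay on HL-60 cells (Homo sapiens) for antiproliferative activity, read by MTT assay, with a stated time of 72 h; on this read-out higher numbers stand for weaker inhibition and lower numbers for stronger inhibition.
Compound 2 `NC1=NC2(CCOCC2)N(OCCCOc2ccc(Cl)cc2)C(N)=N1` gives 330 nM in this assay.
Compound 3 `NC1=NC2(CCOCC2)N(OCCCOc2ccc(Br)cc2)C(N)=N1` gives 310 nM in this assay.

Among these three, compound 1 stands at the highest number, which on this read-out is the weakest inhibition. The measured steps run from compound 1 toward the other two: a 7.2-fold lower number from compound 1 to compound 2 (0.86 log units; beyond the scatter) and a 7.7-fold lower number from compound 1 to compound 3 (0.89 log units; beyond the scatter), both beyond the scatter, while a 1.1-fold lower number from compound 2 to compound 3 (0.03 log units; within the scatter) is within it. Compound 4 `NC1=NC2(CCOCC2)N(OCCCOc2ccccc2)C(N)=N1` differs from compound 1 by hydrogen in place of fluoro on an aromatic carbon. For the measured compounds named here, no measured pair shows this particular exchange, so the expectation rests on indirect reasoning. The two steps from compound 1 show that replacing fluoro by chloro or bromo lowered the number, as seen in a 7.2-fold lower number from compound 1 to compound 2 (0.86 log units; beyond the scatter) and a 7.7-fold lower number from compound 1 to compound 3 (0.89 log units; beyond the scatter). Removing the fluoro altogether moves away from those larger halogens rather than toward them, so no lowering of the number is expected, and a small rise is plausible. Compound 4 is therefore expected to give 3200 nM in this assay, within 1300 nM to 8000 nM, meaning an estimated 1.3-fold higher number from compound 1 to compound 4 (0.13 log units; within the scatter), which may well lie within the scatter.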

Compound 4, half-maximal inhibitory concentration: 2460 nM
Compound 4: middle estimate off by 1.3-fold (0.11 log units), on the high side, and the stated range covers the measured number.
By their numbers in this assay, from the lowest: compounds 3 and 2 (each within the scatter of the next); then compounds 1 and 4 (each within the scatter of the next).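

In this assay, for the compounds shown here, replacing fluoro with hydrogen on the aromatic carbon para to a large group gives a 1.0-fold higher number from compound 1 to compound 4 (0.01 log units; within the scatter), so at this position the fluoro and unsubstituted compounds cannot be told apart, something the earlier compounds, all of which carry a halogen, could not show. Going to hydrogen from the other two halogens gives a 7.9-fold higher number from compound 3 to compound 4 (0.90 log units; beyond the scatter) and a 7.5-fold higher number from compound 2 to compound 4 (0.87 log units; beyond the scatter), so the earlier gap between fluoro and the pair of chloro and bromo reflects a gain that chloro and bromo bring over hydrogen, not a penalty carried by fluoro. No measurement shown here accounts for fluoro matching hydrogen while chloro and bromo differ from it.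

The compounds shown leave open whether iodo would stand with chloro and bromo, and whether a group that is not a halogen, such as methyl, methoxy or trifluoromethyl, would give a similar gain over hydrogen at this place. They also leave open how an amine or a carboxylic acid there would read in this assay, and whether the gain from chloro and bromo would survive a longer chain in place of the present one.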